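Swapping methyl for oxolan-3-yl on a cytotoxic amide

A few compounds are considered here, and "the series" means these few. Any claim that something is new, unique, unknown or untested is made for them only; others in the source may bear on it.

Compound 1 `COc1ccc(/C=C/C(=O)Nc2cc3c(Nc4ccc(F)c(Cl)c4)ncnc3cc2O[C@H]2CCOC2)c(OC)c1` gives 28600 nM
Compound 2 `COc1cc(/C=C/C(=O)Nc2cc3c(Nc4ccc(F)c(Cl)c4)ncnc3cc2OC)cc(OC)c1` gives 38500 nM

In a functional assay on MCF7 cells (Homo sapiens) for cytotoxicity, read by MTT assay, with a stated time of 72 h (a higher number here means a weaker inhibitor, a lower number a stronger inhibitor), compound 2 gives 38500 nM and stands within the scatter of compound 1 (28600 nM). Compound 3 `COc1cc(/C=C/C(=O)Nc2cc3c(Nc4ccc(F)c(Cl)c4)ncnc3cc2O[C@H]2CCOC2)cc(OC)c1` arises from compound 2 by one change (oxolan-3-yl in place of methyl on an oxygen on an aromatic ring), oxolan-3-yl in place of methyl on an oxygen on an aromatic ring. Within the data shown here, no measured pair isolates this change. Compound 1, which also carries (oxolan-3-yl)oxy, gives 28600 nM in this readout, so no step beyond the scatter is expected in this assay. The expected move is a 1.3-fold lower number from compound 2 to compound 3 (0.11 log units; within the scatter) and would stay within the scatter. Compound 3 is estimated at 30000 nM with 12000 nM to 70000 nM as its expected range.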

Compound 3, half-maximal inhibitory concentration: 30300 nM
The estimate for compound 3 lay 1.0-fold (0.00 log units) below the measured number; low and high end bracket the measured number.
By their numbers in this assay, from the lowest: compounds 1, 3 and 2 (each within the scatter of the next).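

In this assay, the change from methoxy to (oxolan-3-yl)oxy now stands as a measured pair, with a 1.3-fold lower number from compound 2 to compound 3 (0.10 log units; within the scatter), so at this position the five-membered ring and its stereocentre leave the number within the scatter. With (oxolan-3-yl)oxy held constant, 3,5-dimethoxyphenyl in place of 2,4-dimethoxyphenyl gives a 1.1-fold higher number from compound 1 to compound 3 (0.03 log units; within the scatter), also within the scatter. Nothing available explains either result. The compounds shown leave open whether an amine, a carboxylic acid or a longer chain on this oxygen would move the number beyond the scatter.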